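Replacing 4-(methylsulfonyl)phenyl with 4-chloro-2-methylphenyl on an Amide

A few compounds are considered here, and "the series" means these few. Any claim that something is new, unique, unknown or untested is made for them only; others in the source may bear on it.

Compound 1 `O=C(Nc1ccc(Cl)c(-c2nnc3c(Cl)cccn23)c1)c1cccnc1` carries pyridin-3-yl on the carbonyl carbon. In a functional assay on MDA-MB-468 cells (Homo sapiens) for antiproliferative activity, read by MTT assay, with a stated time of 72 h (on this read-out higher numbers stand for weaker inhibition and lower numbers for stronger inhibition), compound 1 gives > 100000 nM, a limit of the assay rather than a number. Compound 2 `CS(=O)(=O)c1ccc(C(=O)Nc2ccc(Cl)c(-c3nnc4c(Cl)cccn34)c2)cc1` gives > 100000 nM in this assay, again only a limit. The step that the two limits leave unreadable from compound 1 to compound 2 is therefore unreadable, since (the limit of > 100000 nM in this assay, at which 2 of the 2 values shown sit). Compound 3 `Cc1cc(Cl)ccc1C(=O)Nc1ccc(Cl)c(-c2nnc3c(Cl)cccn23)c1` differs from compound 2 by 4-chloro-2-methylphenyl in place of 4-(methylsulfonyl)phenyl on a carbonyl carbon. Among the compounds with values here, no measured step bears on this change with a readable size, so no direction beyond the scatter can be expected. Compound 3 is estimated at 100000 nM, within 30000 nM to 300000 nM. The expected step is a number no higher from compound 2 to compound 3 (the limit leaves the size open).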

Compound 3, half-maximal inhibitory concentration: 34300 nM
For compound 3 the middle estimate is 2.9-fold (0.46 log units) above the measured one; the range from low to high includes it.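

In this assay, within the data shown here, 4-chloro-2-methylphenyl on the carbonyl carbon gives the first readable value in this set, with an at least 2.9-fold lower number from compound 2 to compound 3 (0.46 log units; beyond the scatter) and an at least 2.9-fold lower number from compound 1 to compound 3 (0.46 log units; beyond the scatter). This shows that a change at this position can move the read-out beyond the scatter, which the two earlier groups could not show. Going by these compounds, the full size of both steps stays open because the starting values are limits: the limit of > 100000 nM in this assay, at which 2 of the 3 values shown sit.

The compounds shown leave open whether the chloro or the methyl group accounts for the step. On these data alone, how an amine or a carboxylic acid on this phenyl ring would read also remains open.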